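The source may hold more compounds than are shown below. What is called first, only, known or untested is meant among the compounds shown, and "the series" means these compounds.

Among the measured compounds shown here, in a functional assay on DU-145 cells (Homo sapiens) for antiproliferative activity, read by propidium iodide staining, with a stated time of 96 h (on this read-out higher numbers stand for weaker inhibition and lower numbers for stronger inhibition), three compounds built on a shared core have numbers so far. Compound 1 `CC(O)(CSc1ccc(S(F)(F)(F)(F)F)cc1)C(=O)Nc1cccc(S(F)(F)(F)(F)F)c1` gives 24800 nM, compound 2 `CC(O)(CSc1ccc(F)cc1)C(=O)Nc1cccc(S(F)(F)(F)(F)F)c1` gives 38500 nM, and compound 3 `CC(O)(CSc1ccc(C(F)(F)F)cc1)C(=O)Nc1cccc(S(F)(F)(F)(F)F)c1` gives 27200 nM. Compound 3 cannot be separated from either of the others: one step is a 1.1-fold higher number from compound 1 to compound 3 (0.04 log units; within the scatter), and the other is a 1.4-fold lower number from compound 2 to compound 3 (0.15 log units; within the scatter).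

Compound 4 `CC(O)(CSc1ccc(OC(F)(F)F)cc1)C(=O)Nc1cccc(S(F)(F)(F)(F)F)c1` carries trifluoromethoxy in place of trifluoromethyl on an aromatic carbon, para to a large group (trifluoromethoxy in place of trifluoromethyl on an aromatic carbon). For the measured compounds named here, no measured step tests this exact exchange, so the closest guide is what other exchanges at this place have done. Those two steps to compound 3 bear on it, as does a 1.6-fold higher number from compound 1 to compound 2 (0.19 log units; within the scatter). All three stayed small, so no shift beyond the scatter is expected in this assay.

The estimated step is a 1.0-fold lower number from compound 3 to compound 4 (0.02 log units; within the scatter).

For compound 4 the expected value is 26000 nM, with an estimated range from 15000 nM to 42000 nM.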

Compound 4, half-maximal inhibitory concentration: 24700 nM
Estimate against measurement, compound 4: 1.1-fold (0.02 log units) above; the measured number falls inside the stated range.
By their numbers in this assay, from the lowest: compounds 4, 1, 3 and 2 (each within the scatter of the next).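

Trifluoromethoxy brings one more heavy atom and one hydrogen-bond acceptor to this aromatic carbon than trifluoromethyl does, yet the exchange does not separate the two compounds (a 1.1-fold lower number from compound 3 to compound 4 (0.04 log units; within the scatter)). Compound 4 also cannot be separated from the fluoro compound (a 1.6-fold lower number from compound 2 to compound 4 (0.19 log units; within the scatter)) or from the compound with pentafluorosulfanyl at this place (a 1.0-fold lower number from compound 1 to compound 4 (0.00 log units; within the scatter)), so these four groups, which differ in size and in acceptor count, give numbers that all lie within the scatter of one another. Nothing measured here explains why the numbers stay so close.

From the compounds shown here alone, whether an amine, a carboxylic acid or a longer chain at this place would move the number beyond the scatter remains open. So does the question of whether any change elsewhere on the shared core would do so.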